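This account rests on a few compounds, and the source may have more. Where it says the series, first, only, none or still open, it means among the compounds named here.

Measured so far:

Compound 1 `NS(=O)(=O)c1ccc(-n2nc(-c3ccc(Cl)cc3)cc2-c2cc(O)ccc2O)cc1` — 14600 nM
Compound 2 `CC(=O)NS(=O)(=O)c1ccc(-n2nc(-c3ccccc3)cc2-c2cc(O)ccc2O)cc1` — 84800 nM
Compound 3 `NS(=O)(=O)c1ccc(-n2nc(-c3ccc(Cl)cc3)cc2C2=CC(=O)C=CC2=O)cc1` — 26700 nM

All three were tested in a functional assay on cells (Melanoma cell, Homo sapiens) for cytotoxicity, read by sulforhodamine B assay, with a stated time of 48 h; on this read-out lower numbers stand for stronger inhibition of growth and higher numbers for weaker inhibition of growth. Compound 1 gives 14600 nM, compound 3 gives 26700 nM, and compound 2 gives 84800 nM, the highest number of the three and beyond the scatter from both others.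

Compound 3 differs from compound 1 by one change, (a group of 8 heavy atoms (6 carbon, 2 oxygen; one six-membered non-aromatic ring of carbon only) in place of a group of 8 heavy atoms (6 carbon, 2 oxygen; one six-membered aromatic ring of carbon only), on an aromatic carbon), and this change made a step of a 1.8-fold higher number from compound 1 to compound 3 (0.26 log units; within the scatter), which is within the scatter, so the two numbers do not tell the two apart.

Compound 4 `CC(=O)NS(=O)(=O)c1ccc(-n2nc(-c3ccccc3)cc2C2=CC(=O)C=CC2=O)cc1` has not yet been measured. It stands to compound 2 as compound 3 stands to compound 1: the change is a group of 8 heavy atoms (6 carbon, 2 oxygen; one six-membered non-aromatic ring of carbon only) in place of a group of 8 heavy atoms (6 carbon, 2 oxygen; one six-membered aromatic ring of carbon only), on an aromatic carbon. The surroundings are not word for word the same, since in compound 1 the place is next to the ring atom that bears a 4-sulfamoylphenyl group and two ring bonds from the ring atom that bears a 4-chlorophenyl group, while in compound 2 it is next to the ring atom that bears a large group and two ring bonds from the ring atom that bears a phenyl group. It is therefore the same kind of change, not the same one. How the cores of compound 1 and compound 2 themselves differ is not broken down here.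

The expectation for compound 4 is a step of about a 1.5-fold higher number from compound 2 to compound 4 (0.19 log units; within the scatter), resting on the earlier step of a 1.8-fold higher number from compound 1 to compound 3 (0.26 log units; within the scatter). The starting point is compound 2, which gives 84800 nM. On that basis compound 4 is estimated at 130000 nM, expected to lie between 50000 nM and 350000 nM.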

Compound 4, concentration for 50% growth inhibition: 92000 nM
Beside the measured number, compound 4's estimate is 1.4-fold (0.15 log units) above it; measured number inside the range.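

In this assay, replacing the 2,5-dihydroxyphenyl group with the non-aromatic six-membered ring gives a 1.1-fold higher number from compound 2 to compound 4 (0.04 log units; within the scatter), so the numbers do not tell these two groups apart on this core. The earlier pair gave the same kind of result, and the two steps themselves cannot be told apart: the same change on two cores in this assay, a 1.8-fold higher number (0.26 log units; within the scatter) from compound 1 to compound 3 and a 1.1-fold higher number (0.04 log units; within the scatter) from compound 2 to compound 4, 1.7-fold (0.23 log units) apart, within the scatter of two such steps

For the compounds shown here, this shows that, on these two cores, the swap carried across without a step beyond the scatter, even though the entering ring has no hydrogen-bond donors and the group it replaces has them; it does not show that the two groups are interchangeable in general, since the evidence is only two pairs, in one assay, and all four numbers are high on this read-out.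

On these data alone, whether the same holds on a third core remains open, for instance one that joins the 4-chlorophenyl group of compound 1 to the sulfonamide of compound 2. Also open, as far as these compounds go, is whether a different group in the same place, such as a 2,5-dimethoxyphenyl group, a plain phenyl group or an amine, would give a step beyond the scatter.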